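From Acetoxymethyl to Thiophene on a Triazole-Bearing Nucleoside

This account rests on a few compounds, and the source may have more. Where it says the series, first, only, none or still open, it means among the compounds named here.

Three compounds share one core and differ only in the group carried by the triazole ring. Compound 1 `CCS[C@@H]1[C@H](SCC)[C@@H](Cn2cc(-c3ccc(OC)cc3)nn2)O[C@H]1n1ccc(=O)[nH]c1=O` bears a 4-methoxyphenyl group; in a functional assay on HeLa cells (Homo sapiens) for cytotoxicity, read by MTT assay, with a stated time of 72 h (on this read-out higher numbers stand for an effect only at larger amounts of compound and lower numbers for an effect already at smaller amounts), compound 1 gives 27700 nM. Compound 2 `CCS[C@@H]1[C@H](SCC)[C@@H](Cn2cc(-c3cccc(C)c3)nn2)O[C@H]1n1ccc(=O)[nH]c1=O` bears a 3-methylphenyl group and in this assay compound 2 gives 18800 nM. Compound 3 `CCS[C@@H]1[C@H](SCC)[C@@H](Cn2cc(COC(C)=O)nn2)O[C@H]1n1ccc(=O)[nH]c1=O` bears an acetoxymethyl group instead of an aromatic ring. For compound 3 this assay reports only a limit, >= 100000 nM, namely (the limit of >= 100000 nM in this assay, at which 1 of the 3 values shown sits). Among the numbers shown, compound 3 therefore stands at the weak end. The two steps leading to it were an at least 3.6-fold higher number from compound 1 to compound 3 (0.55 log units; beyond the scatter) and an at least 5.3-fold higher number from compound 2 to compound 3 (0.72 log units; beyond the scatter), while a 1.5-fold lower number from compound 1 to compound 2 (0.17 log units; within the scatter). So far, exchanging one aromatic ring for another has left the number roughly where it was, whereas replacing the ring by acetoxymethyl has pushed it past the limit.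

Compound 4 `CCS[C@@H]1[C@H](SCC)[C@@H](Cn2cc(-c3cccs3)nn2)O[C@H]1n1ccc(=O)[nH]c1=O` is the next case: thiophen-2-yl in place of acetoxymethyl on an aromatic carbon. This brings an aromatic ring back to the same position as in compounds 1 and 2, so a step in the opposite direction to those two measured steps is expected, beyond the scatter: an at least 4.0-fold lower number from compound 3 to compound 4 (0.60 log units; beyond the scatter). In this assay compound 4 is estimated at 25000 nM, with a likely range from 10000 nM to 90000 nM.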

Compound 4, half-maximal effective concentration: >= 100000 nM
Compound 4: a limit, no number (the forecaster's own chance of this, stated with the estimate: 20%); at least 4.0-fold (0.60 log units) between middle value and limit.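

In this assay, putting thiophen-2-yl in place of a substituted phenyl ring gives an at least 5.3-fold higher number from compound 2 to compound 4 (0.72 log units; beyond the scatter) and an at least 3.6-fold higher number from compound 1 to compound 4 (0.55 log units; beyond the scatter). An aromatic ring on this triazole carbon is therefore not enough by itself to give a readable number among these compounds, and the line between compounds 1 and 2 on one side and compounds 3 and 4 on the other is not simply ring against no ring, since compound 4 carries a ring and compound 3 does not. The step from compound 3 to compound 4 cannot be read, and the two groups cannot be ranked, because both compounds stand at a limit and not at a number: the limit of >= 100000 nM in this assay, at which 2 of the 4 values shown sit.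

An unsubstituted phenyl group or a thiophen-2-yl ring carrying a methyl group would be needed to tell whether the kind of ring or the methyl and methoxy groups on the rings of compounds 1 and 2 set those two apart. On these data alone, how far compound 3 and compound 4 lie past the limit stays open, as does how an aminomethyl group or a carboxylic acid would read at this position.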